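Dimethoxyphenyl replaces dichlorophenyl on the ketone of compound 1

This account rests on a few compounds, and the source may have more. Where it says the series, first, only, none or still open, it means among the compounds named here.

Compound 1 `COc1cc(-c2cc(/C=C/C(=O)c3ccc(Cl)c(Cl)c3)[nH]n2)cc(OC)c1OC`: 24000 nM
Compound 2 `COc1ccc(-c2cc(/C=C/C(=O)c3ccc(N)cc3)[nH]n2)cc1OC`: 4560 nM

Going by the values given here, in a functional assay on IGROV-1 cells (Homo sapiens) for inhibition, read by sulforhodamine B assay, with a stated time of 48 h (on this read-out lower numbers stand for stronger inhibition of growth and higher numbers for weaker inhibition of growth), compound 1 gives 24000 nM, the higher of the two numbers known so far. Compound 2 gives 4560 nM, a lower number that lies beyond the scatter. Compound 3 `COc1ccc(C(=O)/C=C/c2cc(-c3cc(OC)c(OC)c(OC)c3)n[nH]2)cc1OC` differs from compound 1 in one place: 3,4-dimethoxyphenyl in place of 3,4-dichlorophenyl on a carbonyl carbon. Among the compounds with values here, no pair of measured compounds shows this change, so the expectation rests on the general level of the two numbers. A downward step of moderate size is expected, a 2.4-fold lower number from compound 1 to compound 3 (0.38 log units; beyond the scatter), because compound 2 already reaches 4560 nM with a different group on the carbonyl carbon. Compound 3 is expected to give 10000 nM, within 3500 nM to 30000 nM.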

Compound 3, concentration for 50% growth inhibition: 1800 nM
Estimate against measurement, compound 3: 5.6-fold (0.74 log units) above; measured number outside the range, below it.
By their numbers in this assay, from the lowest: compound 3; then compound 2; then compound 1.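

In this assay the group on the carbonyl carbon carries real weight: with the rest of compound 1 kept, 3,4-dimethoxyphenyl in place of 3,4-dichlorophenyl gives a 13-fold lower number from compound 1 to compound 3 (1.12 log units; beyond the scatter) in this single-place comparison, the first one available at this position. Nothing at hand explains the size of this step.

On these data alone, it remains open whether one methoxy group alone on that phenyl ring would give a similar number. Also open, as far as these compounds go, is how a hydroxy or trifluoromethyl group there would read.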